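The source may hold more compounds than are shown below. What is called first, only, known or untested is meant among the compounds shown, and "the series" means these compounds.

Going by the values given here, in a functional assay on HepG2 cells (Homo sapiens) for antiproliferative activity, read by CCK-8 assay, with a stated time of 72 h (a higher number here means a weaker inhibitor, a lower number a stronger inhibitor), compound 2 `O=C(NO)c1ccc(COc2ccccc2)cc1` gives 29600 nM, the highest of the two numbers so far, while compound 1 `C/C(=N\O)c1ccc(OCc2ccc(C(=O)NO)cc2)cc1` gives 7770 nM. Compound 3 `Nc1cc(F)ccc1NC(=O)c1ccc(COc2ccccc2)cc1` departs from compound 2 through one change, 2-amino-4-fluorophenyl in place of hydroxy on an amide-type nitrogen. Among the compounds with values here, the only measured step, a 3.8-fold higher number from compound 1 to compound 2 (0.58 log units; beyond the scatter), is modest but beyond the scatter. It concerns an aromatic carbon and not the amide-type nitrogen, so no measurement bears directly on this change, and that step serves only as a rough guide to size. The data do not fix a direction, but a modest move toward a lower number is tentatively expected, and the expected step is a 2.5-fold lower number from compound 2 to compound 3 (0.39 log units; beyond the scatter). For compound 3 the estimated value is 12000 nM, with an expected range from 2500 nM to 50000 nM.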

Compound 3, half-maximal inhibitory concentration: 7020 nM
The estimate for compound 3 lay 1.7-fold (0.23 log units) above the measured number, and the stated range covers the measured number.
By their numbers in this assay, from the lowest: compounds 3 and 1 (each within the scatter of the next); then compound 2.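

Going by these compounds alone, at the amide-type nitrogen, the first measured change in this assay is the replacement of hydroxy by 2-amino-4-fluorophenyl, which gives a 4.2-fold lower number from compound 2 to compound 3 (0.62 log units; beyond the scatter). Within the data shown here, the earlier step concerned an aromatic carbon, so this is the first sign that the group on this nitrogen also moves the number, and that the hydroxy is not needed for a value at the level of compound 3. Nothing available accounts for the size or direction of this step.

The compounds shown leave open whether the amino group, the fluorine or the aromatic ring itself carries the step, which a plain phenyl or a 2-aminophenyl at the same nitrogen would help separate. They also leave open how an alkyl group such as methyl would fare there.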